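A Chloro-Methoxyphenyl Swap Under a Stability Ceiling

The compounds below may be only part of what the source reports. "The series", "measured", "known", "first", "only" and "open" are said of these compounds alone.

Compound 1 `N#Cc1ccc(-c2nc(NCCNc3ccc([N+](=O)[O-])c(N)n3)ncc2-c2ncc[nH]2)cc1`, compound 2 `Nc1nc(NCCNc2ncc(-c3ncc[nH]3)c(-c3cc(F)c(F)cc3F)n2)ccc1[N+](=O)[O-]` and compound 3 `Nc1nc(NCCNc2ncc(-c3ncc[nH]3)c(-c3ccc(Br)cc3Cl)n2)ccc1[N+](=O)[O-]` share one core and were all run in an ADME assay on microsomes from liver (Canis lupus familiaris) for metabolic stability; on this read-out higher numbers stand for a longer-lived compound and lower numbers for a shorter-lived compound. Compound 1 gives > 0.5 h, which is a limit of the assay and not a number. Compound 2 gives > 0.5 h, also a limit. Compound 3 gives > 0.5 h, again a limit. Compound 2 therefore stands at the limit of > 0.5 h in this assay, at which 3 of the 3 values shown sit, with no number to compare against its neighbours. The steps a step that the two limits leave unreadable from compound 1 to compound 2, a step that the two limits leave unreadable from compound 1 to compound 3 and a step that the two limits leave unreadable from compound 2 to compound 3 cannot be read. Compound 4 `COc1cc(Cl)ccc1-c1nc(NCCNc2ccc([N+](=O)[O-])c(N)n2)ncc1-c1ncc[nH]1` differs from compound 2 by 4-chloro-2-methoxyphenyl in place of 2,4,5-trifluorophenyl on an aromatic carbon. Within the data shown here, no measured step bears readably on this change. Compound 4 is expected to sit at the same limit, a step that the limit leaves unreadable from compound 2 to compound 4, with an estimate of 1.5 h between 0.5 h and 5 h.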

Compound 4, half-life: > 0.5 h
Compound 4: only a limit was reported; the forecaster's own chance of this, stated with the estimate: 80%; the middle value does not contradict the limit.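

Among these compounds, compound 4 joins compound 1, compound 2 and compound 3 at one limit, so no step to compound 4 can be read: the limit of > 0.5 h in this assay, at which 4 of the 4 values shown sit. In this assay, as far as these compounds go, the actual half-life of each compound, and any order among them, stays open.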